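The source may hold more compounds than are shown below. What is called first, only, known or untested is meant among the compounds shown, and "the series" means these compounds.

Values so far in a functional assay on microsomes from liver (Rattus norvegicus, strain Wistar) for inhibition, with a stated time of 15 min; a higher number here means a weaker inhibitor, a lower number a stronger inhibitor
compound 1 `COc1cc(C2CC(c3cc4ccccc4o3)=NN2C(=O)Nc2cccc(O)c2)ccc1O` gives 24000000 nM
compound 2 `COc1cc(C2CC(c3cc4ccccc4o3)=NN2C(=O)Nc2ccc(F)cc2)ccc1O` gives 125000000 nM
compound 3 `COc1cc(NC(=O)N2N=C(c3cc4ccccc4o3)CC2c2ccc(O)c(OC)c2)ccc1O` is not yet measured

Compound 2 holds the higher of the two numbers, which makes it the weaker inhibitor of the pair. The next change is 4-hydroxy-3-methoxyphenyl in place of 4-fluorophenyl on an amide-type nitrogen. Within the data shown here, one measured step bears on it, and that step also moves away from 4-fluorophenyl when read in reverse: a 5.2-fold higher number from compound 1 to compound 2 (0.72 log units; beyond the scatter). Among the measured compounds shown here, no measured compound carries the entering group, so this comparison is only a rough guide. In this assay a modest move toward a lower number is expected, similar in size to that step, and the expected change is a 3.6-fold lower number from compound 2 to compound 3 (0.55 log units; beyond the scatter). Compound 3 is estimated at 35000000 nM, with an expected range from 10000000 nM to 120000000 nM.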

Compound 3, half-maximal inhibitory concentration: 12000000 nM
Estimate against measurement, compound 3: 2.9-fold (0.46 log units) above, within the range that was stated.
By their numbers in this assay, from the lowest: compounds 3 and 1 (each within the scatter of the next); then compound 2.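

In this assay, 4-hydroxy-3-methoxyphenyl in place of 4-fluorophenyl on the amide-type nitrogen gives a 10-fold lower number from compound 2 to compound 3 (1.02 log units; beyond the scatter), the largest step among the three compounds. Against the 3-hydroxyphenyl group the same entering group gives a 2.0-fold lower number from compound 1 to compound 3 (0.30 log units; within the scatter), so compound 1 and compound 3 stand level, and both hydroxy-bearing groups sit apart from the 4-fluorophenyl group of compound 2. Nothing on hand explains either step.

The compounds shown leave open whether the hydroxy group alone accounts for the gap to compound 2, or whether the methoxy group contributes anything. A plain phenyl, a 4-methoxyphenyl or a 4-aminophenyl group at this nitrogen would help separate these readings.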